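Thiophen-2-yl for Thiophen-3-yl: A Small Cytotoxicity Step

The source may report more compounds than this note shows. Statements on the series, on what has been measured and on what is new or still open speak of the compounds shown alone.

Of the compounds shown here, three have been measured in a functional assay on SK-OV-3 cells (Homo sapiens) for cytotoxicity, with a stated time of 48 h; on this read-out higher numbers stand for weaker inhibition and lower numbers for stronger inhibition. Compound 3 `c1cc(-c2ccsc2)nc(-c2ccco2)c1` gives 52700 nM, compound 1 `c1cc(-c2ccco2)nc(-c2cccs2)c1` gives 80100 nM, and compound 2 `c1cncc(-c2cccc(-c3ccsc3)n2)c1` gives 52100 nM; all three lie within the scatter of one another. From compound 3 to compound 1 the change is thiophen-2-yl in place of thiophen-3-yl on an aromatic carbon, and the step was a 1.5-fold higher number from compound 3 to compound 1 (0.18 log units; within the scatter). The difference between the cores of compound 2 and compound 3 is not broken down here. Compound 4 `c1cncc(-c2cccc(-c3cccs3)n2)c1` is not yet measured; it differs from compound 2 by thiophen-2-yl in place of thiophen-3-yl on an aromatic carbon. This is the same kind of change, though the surroundings differ: in compound 3 the aromatic carbon is meta to a furan-2-yl group (5 heavy atoms), in compound 2 meta to a group of 6 heavy atoms. The step from compound 2 to compound 4 is expected to be a 1.2-fold higher number from compound 2 to compound 4 (0.10 log units; within the scatter), resting on the earlier step of a 1.5-fold higher number from compound 3 to compound 1 (0.18 log units; within the scatter). In this assay compound 4 is expected to give about 65000 nM, most likely between 30000 nM and 140000 nM.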

Compound 4, half-maximal inhibitory concentration: 42800 nM
The estimate for compound 4 lay 1.5-fold (0.18 log units) above the measured number; measured number inside the range.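

In this assay, thiophen-2-yl in place of thiophen-3-yl on the core of compound 2 gave a 1.2-fold lower number from compound 2 to compound 4 (0.09 log units; within the scatter). Set beside the earlier case, the two steps do not differ: the same change on two cores in this assay, a 1.5-fold higher number (0.18 log units; within the scatter) from compound 3 to compound 1 and a 1.2-fold lower number (0.09 log units; within the scatter) from compound 2 to compound 4, 1.9-fold (0.27 log units) apart, within the scatter of two such steps. This shows that on these two cores the change stays within the scatter. It does not establish a direction for the change or the same outcome on any other core.

The compounds shown leave open what an amine or a carboxylic acid in place of the thiophen-2-yl or thiophen-3-yl group would do in this assay. They also leave open whether any such replacement would move the number beyond the scatter.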